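The compounds below may be only part of what the source reports. "The series", "measured", "known", "first", "only" and "open" are said of these compounds alone.

Measured in a functional assay on CCRF-CEM cells (Homo sapiens) for antiproliferative activity, read by cell counting, with a stated time of 2 days; on this read-out lower numbers stand for stronger inhibition and higher numbers for weaker inhibition:
- compound 1 `COc1ccc(C(=O)c2sc(N3CCCC3)nc2N)cc1OC`: 19000 nM
- compound 2 `COc1ccc(C(=O)c2sc(N3CCCC3)nc2N)cc1`: > 200000 nM (a limit, not a number)
- compound 3 `COc1cccc(C(=O)c2sc(N3CCCC3)nc2N)c1`: > 200000 nM (a limit, not a number)

Compound 2 gives no number in this assay, only the limit > 200000 nM. This is the limit of > 200000 nM in this assay, at which 2 of the 3 values shown sit.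

Compound 4 `Nc1nc(N2CCCC2)sc1C(=O)c1ccc(Br)cc1` keeps the shared core of compound 2 and carries bromo in place of methoxy on an aromatic carbon, para to a large group: bromo in place of methoxy on an aromatic carbon.

Among the compounds with values here, no measured step makes this exchange, so the evidence is indirect. Within the data shown here, two steps bear on it, both large and beyond the scatter, and both remove a methoxy from compound 1: an at least 10-fold higher number from compound 1 to compound 2 (1.02 log units; beyond the scatter) and an at least 10-fold higher number from compound 1 to compound 3 (1.02 log units; beyond the scatter). As far as these compounds go, both end at the limit, so their full size is unknown. Compound 1 alone gives a number, and compound 4 has none of its methoxy groups. For this reason, no large move towards a lower number is expected in this assay, and compound 4 may well stay at the limit.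

The expected change is none beyond the scatter, namely an at least 1.3-fold lower number from compound 2 to compound 4 (0.12 log units; that floor lies within the scatter). Compound 4 is estimated at 150000 nM, with an expected range of 40000 nM to 200000 nM.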

Compound 4, half-maximal inhibitory concentration: > 200000 nM
Compound 4 ended at the assay's limit; the forecaster's own chance of this, stated with the estimate: 60%; middle value at least 1.3-fold (0.12 log units) away from the limit.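

In this assay compound 4 gives > 200000 nM, a limit and not a number. Compound 2 also stands at a limit, so no step can be read between compound 2 and compound 4: the limit of > 200000 nM in this assay, at which 3 of the 4 values shown sit.

The compounds shown leave open whether bromo in place of methoxy on an aromatic carbon changes antiproliferative activity at all.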